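This account rests on a few compounds, and the source may have more. Where it says the series, first, only, none or still open, it means among the compounds named here.

Measured so far:
compound 1 `Cc1cc(NC(=O)Nc2ccc(C(C)(C)C)cc2)c2ccccc2n1` — in an ADME assay on Raji cells (Homo sapiens) for cytotoxicity, with a stated time of 72 h (on this read-out lower numbers stand for an effect already at smaller amounts and higher numbers for an effect only at larger amounts of compound), only a limit, > 25000 nM
compound 2 `Cc1ccc(NC(=O)Nc2cc(C)nc3ccccc23)cc1` — in this assay only a limit, > 25000 nM

Compound 2 thus stands at the limit of this assay; no number is known for it. Within the data shown here, the one measured step, a step that the two limits leave unreadable from compound 1 to compound 2, cannot be read because both of its ends sit at the limit of > 25000 nM in this assay, at which 2 of the 2 values shown sit. Compound 3 `Cc1cc(NC(=O)Nc2cccc(Cl)c2)c2ccccc2n1` differs from compound 2 by 3-chlorophenyl in place of 4-methylphenyl on an amide-type nitrogen. Among the measured compounds shown here, no measured step bears on this change, so neither a size nor a direction beyond the scatter can be foreseen. The expected step is a step that the limit leaves unreadable from compound 2 to compound 3. For compound 3 the estimate is 30000 nM, within 8000 nM to 100000 nM, and most likely again only a limit.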

Compound 3, half-maximal effective concentration: 18000 nM
For compound 3 the middle estimate is 1.7-fold (0.22 log units) above the measured one; the measured number falls inside the stated range.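

With 3-chlorophenyl in place of 4-methylphenyl on an amide-type nitrogen, this assay yields its only readable number among these compounds, and the change reads as an at least 1.3-fold lower number from compound 2 to compound 3 (0.14 log units; that floor lies within the scatter). Only a floor is known for this step, so the true difference may be larger, but what is shown does not clear the usual scatter. Compound 1 and compound 2 give a limit and no number: the limit of > 25000 nM in this assay, at which 2 of the 3 values shown sit.

Still open, as far as these compounds go, is how the number would move with an amine or a carboxylic acid in place of the chlorine. Also open, from the compounds shown here alone, is whether any group at this position gives a step clearly beyond the scatter.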